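Alkyl chains on the shared core: working notes

The compounds below may be only part of what the source reports. "The series", "measured", "known", "first", "only" and "open" are said of these compounds alone.

- compound 1 `CCCn1ccnc1/C=C/C(=O)/C=C/c1coc2ccccc2c1=O`: 2100 nM
- compound 2 `CCCCn1ccnc1/C=C/C(=O)/C=C/c1coc2ccccc2c1=O`: 2000 nM
- compound 3 `CC(C)CCn1ccnc1/C=C/C(=O)/C=C/c1coc2ccccc2c1=O`: 4000 nM
- compound 4 `CCCC(C)n1ccnc1/C=C/C(=O)/C=C/c1coc2ccccc2c1=O`: not yet measured

All values come from a functional assay on LNCaP cells (Homo sapiens) for inhibition, read by WST assay, with a stated time of 3 days; on this read-out higher numbers stand for weaker inhibition and lower numbers for stronger inhibition. Compound 3, at 4000 nM, stands within the scatter of the other two compounds: the data show a 1.9-fold higher number from compound 1 to compound 3 (0.28 log units; within the scatter) and a 2.0-fold higher number from compound 2 to compound 3 (0.30 log units; within the scatter).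

The next change puts 1-methylbutyl in place of isopentyl on an aromatic nitrogen. The remaining measured chain change is a 1.1-fold lower number from compound 1 to compound 2 (0.02 log units; within the scatter). Within the data shown here, these three steps bear on the change only indirectly, since no measured compound carries 1-methylbutyl. With all three within the scatter, no step beyond the scatter is expected in this assay, in either direction, though this rests on thin evidence.

The estimated change is a 1.3-fold lower number from compound 3 to compound 4 (0.12 log units; within the scatter). For compound 4 the expected value is 3000 nM, with an estimated range of 1200 nM to 7500 nM.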

Compound 4, half-maximal inhibitory concentration: 3900 nM
The estimate for compound 4 lay 1.3-fold (0.11 log units) below the measured number; measured number inside the range.
By their numbers in this assay, from the lowest: compounds 2, 1, 4 and 3 (each within the scatter of the next).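

In this assay the exchange of isopentyl for 1-methylbutyl on an aromatic nitrogen gives a 1.0-fold lower number from compound 3 to compound 4 (0.01 log units; within the scatter) with the same atoms joined differently, so this rearrangement of the chain is not registered. Methyl on the saturated chain carbon bound to the aromatic nitrogen, a branch absent from the earlier compounds, gives a 2.0-fold higher number from compound 2 to compound 4 (0.29 log units; within the scatter) and 1-methylbutyl in place of propyl gives a 1.9-fold higher number from compound 1 to compound 4 (0.27 log units; within the scatter) as the two further steps, so this branch does not separate compound 4 from the unbranched chains. No data are available that would account for these results.

Going by these compounds, whether an amine, a carboxylic acid or a longer chain such as octyl on this aromatic nitrogen would leave the number within the scatter remains open. The same holds for the shorter methyl and ethyl groups.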